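Thiophene to furan on a shared nucleoside core

The compounds below may be only part of what the source reports. "The series", "measured", "known", "first", "only" and "open" are said of these compounds alone.

Compound 3 has the structure `Nc1nc(N)c2c(-c3cccs3)cn([C@@H]3O[C@H](CO)[C@@H](O)[C@H]3O)c2n1`. In an ADME assay on BJ cells (Homo sapiens), read by MTT assay, with a stated time of 72 h (a lower number here means a stronger inhibitor, a higher number a weaker inhibitor), compound 3 gives > 100000 nM, which is a limit of the assay and not a number. Two related compounds are known in the same assay. Compound 1, with the structure `Nc1nc(N)c2c(-c3ccsc3)cn([C@@H]3O[C@H](CO)[C@@H](O)[C@H]3O)c2n1`, differs from compound 3 in one place only; in this assay compound 1 gives > 100000 nM, again a limit. Compound 2, with the structure `Cc1nc(N)c2c(-c3ccoc3)cn([C@@H]3O[C@H](CO)[C@@H](O)[C@H]3O)c2n1`, gives > 100000 nM in this assay, likewise a limit. Among the measured compounds shown here, the only measured step, a step that the two limits leave unreadable from compound 1 to compound 3, cannot be read in size because of the limit of > 100000 nM in this assay, at which 3 of the 3 values shown sit. Compound 3 therefore stands at the limit together with the other two.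

Compound 4 has the structure `Nc1nc(N)c2c(-c3ccoc3)cn([C@@H]3O[C@H](CO)[C@@H](O)[C@H]3O)c2n1`. The change from compound 3 is furan-3-yl in place of thiophen-2-yl on an aromatic carbon. For the measured compounds named here, no measured step bears directly on this change: the step from compound 1 to compound 3 concerns the thiophene alone, and compound 2 carries a further change on the shared core besides the furan. With every value shown being a limit, the expectation for compound 4 is that it also sits at the limit, and the step that the limit leaves unreadable from compound 3 to compound 4 is expected to be none beyond the scatter. The estimated value for compound 4 in this assay is 150000 nM, with a range from 60000 nM to 400000 nM.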

Compound 4, half-maximal inhibitory concentration: > 100000 nM
Compound 4 gave a limit, no number; the forecaster's own chance of this, stated with the estimate: 85%; the middle value is on the limit's open side.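

Compound 4 also gives a limit of the assay and not a number, so no step among compound 1, compound 2, compound 3 and compound 4 can be read in size: the limit of > 100000 nM in this assay, at which 4 of the 4 values shown sit.

The compounds shown leave open whether any of these changes on the shared core alters the read-out in this assay at all.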